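Adding an arylsulfonyl group to compound 1

The source may hold more compounds than are shown below. What is called first, only, known or untested is meant among the compounds shown, and "the series" means these compounds.

Measured so far in a functional assay on HeLa cells (Homo sapiens) for antiproliferative activity, read by MTT assay, with a stated time of 24 h; a lower number here means a stronger inhibitor, a higher number a weaker inhibitor

Compound 1 `Cc1ccc(-c2nn(-c3ccccc3)cc2-c2nc3ccccc3[nH]2)cc1` gives 4950 nM
Compound 2 `Cc1ccc(-c2nn(-c3ccccc3)cc2-c2nc3ccccc3n2S(=O)(=O)c2ccc(C)cc2)cc1` gives 480 nM

Compound 1 has the higher of the two numbers, so it is the weaker inhibitor of this pair. Compound 3 `Cc1ccc(-c2nn(-c3ccccc3)cc2-c2nc3ccccc3n2S(=O)(=O)c2ccc(F)cc2)cc1` has not yet been measured. It differs from compound 1 by (4-fluorophenyl)sulfonyl in place of hydrogen on an aromatic nitrogen in one change, (4-fluorophenyl)sulfonyl in place of hydrogen on an aromatic nitrogen. Among the measured compounds shown here, one measured step bears on it: a 10-fold lower number from compound 1 to compound 2 (1.01 log units; beyond the scatter) when (4-methylphenyl)sulfonyl takes the place of hydrogen on an aromatic nitrogen. That step is large, so a similar large move towards a lower number is expected in this assay for the new compound. The expected change is a 9.9-fold lower number from compound 1 to compound 3 (1.00 log units; beyond the scatter) on this single piece of evidence. Compound 3 is estimated at 500 nM with an expected range from 180 nM to 1400 nM once it is measured.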

Compound 3, half-maximal inhibitory concentration: 3670 nM
Beside the measured number, compound 3's estimate is 7.3-fold (0.87 log units) below it; the measured number lies above the stated range.
By their numbers in this assay, from the lowest: compound 2; then compounds 3 and 1 (each within the scatter of the next).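

In this assay, (4-fluorophenyl)sulfonyl in place of hydrogen on the aromatic nitrogen gives a 1.3-fold lower number from compound 1 to compound 3 (0.13 log units; within the scatter), so compound 1 and compound 3 cannot be told apart here, and a sulfonyl group on this nitrogen does not by itself bring the gain. Fluoro in place of methyl on an aromatic carbon gives a 7.6-fold higher number from compound 2 to compound 3 (0.88 log units; beyond the scatter), so among these three compounds the gain goes with the (4-methylphenyl)sulfonyl group of compound 2 and is absent with the (4-fluorophenyl)sulfonyl group. No measurement at hand explains this difference between methyl and fluoro.

From the compounds shown here alone, it remains open whether chloro, methoxy or an amine in place of that methyl would behave like methyl or like fluoro. Also open, going by these compounds, is how a methylsulfonyl group, which has no aromatic ring, would behave on the same nitrogen.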